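The source may report more compounds than this note shows. Statements on the series, on what has been measured and on what is new or still open speak of the compounds shown alone.

Working notes on the series.

Compound 1 `C=CC1=C(C(=O)NCc2ccccc2F)C(c2ccc(F)cc2)OC1` sits at the weak end of the few numbers available: in a functional assay on SW480 cells (Homo sapiens) for cytotoxicity, read by MTT assay, with a stated time of 24 h (on this read-out higher numbers stand for weaker inhibition and lower numbers for stronger inhibition), compound 1 gives > 100000 nM, which is a limit of the assay rather than a number. Compound 2 `C=CC1=C(C(=O)NCc2ccccc2)C(c2ccc(OC)cc2)OC1` carries benzyl on the amide-type nitrogen and a methoxyphenyl on the core, and in this assay compound 2 gives 39500 nM. Compound 3 `C=CC1=C(C(=O)Nc2ccc(OCC)cc2)C(c2ccc(OC)cc2)OC1` gives > 100000 nM in this assay, again a limit. Within the data shown here, the one measured step, an at least 2.5-fold higher number from compound 2 to compound 3 (0.40 log units; beyond the scatter), concerns the group on the amide-type nitrogen itself, not the ring on the benzyl carbon, so it does not bear directly on the change to compound 4 `C=CC1=C(C(=O)NCc2ccc(Cl)cc2)C(c2ccc(F)cc2)OC1`. That change, (4-chlorophenyl in place of 2-fluorophenyl on a saturated chain carbon bound to an amide-type nitrogen), has no measured parallel here; the series is thin, with the limit of > 100000 nM in this assay, at which 2 of the 3 values shown sit, setting where most values rest. No step beyond the scatter is therefore expected in this assay in either direction, and compound 4 is estimated at 90000 nM (range 30000 nM to 300000 nM), with an at least 1.1-fold lower number from compound 1 to compound 4 (0.04 log units; that floor lies within the scatter) expected to be small.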

Compound 4, half-maximal inhibitory concentration: > 100000 nM
Compound 4 gave a limit, no number (the forecaster's own chance of this, stated with the estimate: 60%); middle value at least 1.1-fold (0.04 log units) from the limit.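

Compound 1 and compound 4 both end at a limit of this assay, not at a number, so no step can be read between them: the limit of > 100000 nM in this assay, at which 3 of the 4 values shown sit. The compounds shown leave open whether 2-fluorophenyl and 4-chlorophenyl at this place differ at all in this assay.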